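A Small Furan Ring Replaces the Biphenyl Ketone

This account rests on a few compounds, and the source may have more. Where it says the series, first, only, none or still open, it means among the compounds named here.

Compound 1 `COc1cc(-c2nnc3n2NC(c2ccco2)C(C(=O)c2cccc4ccccc24)S3)cc(OC)c1OC`: in a functional assay on A549 cells (Homo sapiens) for cytotoxicity, read by MTT assay, with a stated time of 48 h (a lower number here means a stronger inhibitor, a higher number a weaker inhibitor), compound 1 gives > 100000 nM, which is a limit of the assay.
Compound 2 `COc1cc(-c2nnc3n2NC(c2ccco2)C(C(=O)c2ccc(C(F)(F)F)cc2)S3)cc(OC)c1OC`: in this assay compound 2 gives 37200 nM.
Compound 3 `COc1cc(-c2nnc3n2NC(c2ccco2)C(C(=O)c2ccc(-c4ccccc4)cc2)S3)cc(OC)c1OC`: in this assay compound 3 gives > 100000 nM, again only a limit.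

Compound 3 therefore stands at the edge of what was measured, sharing (the limit of > 100000 nM in this assay, at which 2 of the 3 values shown sit). Compound 4 `COc1cc(-c2nnc3n2NC(c2ccco2)C(C(=O)c2ccco2)S3)cc(OC)c1OC` differs from compound 3 by furan-2-yl in place of 4-phenylphenyl on a carbonyl carbon. The measured steps that bear on this position are an at least 2.6-fold lower number from compound 1 to compound 2 (0.42 log units; beyond the scatter) and an at least 2.6-fold higher number from compound 2 to compound 3 (0.42 log units; beyond the scatter), while a step that the two limits leave unreadable from compound 1 to compound 3. Among the compounds with values here, only the 4-(trifluoromethyl)phenyl of compound 2 gave a readable number on this carbonyl carbon, and a furan-2-yl has no precedent here, so the expected step of an at least 1.6-fold lower number from compound 3 to compound 4 (0.22 log units; that floor lies within the scatter) is uncertain. Compound 4 is estimated at 60000 nM, between 15000 nM and 200000 nM, with a real chance that only a limit is reported.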

Compound 4, half-maximal inhibitory concentration: 68700 nM
Estimate against measurement, compound 4: 1.1-fold (0.06 log units) below; the measured number falls inside the stated range.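

On this carbonyl carbon, a second group now gives a readable number in this assay, with a 1.8-fold higher number from compound 2 to compound 4 (0.27 log units; within the scatter), so furan-2-yl and 4-(trifluoromethyl)phenyl cannot be told apart here. The other two comparisons, an at least 1.4-fold lower number from compound 3 to compound 4 (0.16 log units; that floor lies within the scatter) and an at least 1.4-fold lower number from compound 1 to compound 4 (0.16 log units; that floor lies within the scatter), do not establish that furan-2-yl outperforms 4-phenylphenyl or naphthalen-1-yl. Those two floors rest on a limit of the assay, not on a number: the limit of > 100000 nM in this assay, at which 2 of the 4 values shown sit.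

As far as these compounds go, whether a pyridine ring or a simple alkyl chain on this carbonyl carbon would give a clearly lower number remains open.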